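A few compounds are considered here, and "the series" means these few. Any claim that something is new, unique, unknown or untested is made for them only; others in the source may bear on it.

Compound 1 `O=C(O)c1cccc(OCc2ccc(OCc3c(-c4c(Cl)cccc4Cl)noc3C3CC3)nc2C(F)(F)F)c1` gives in an assay on isolated protein for agonist activity at Bile acid receptor (Homo sapiens), read by FRET (on this read-out lower numbers stand for smaller maximal responses and higher numbers for larger maximal responses), a maximal response of 98%. Compound 2 `O=C(O)c1ccc(OCc2ccc(OCc3c(-c4c(Cl)cccc4Cl)noc3C3CC3)nc2C(F)(F)F)cc1` gives in this assay 86%. The change between the two, (4-carboxyphenyl in place of 3-carboxyphenyl on an oxygen on a saturated carbon), made a number 12 percentage points lower from compound 1 to compound 2 (beyond the scatter). Compound 3 `CC(Oc1cccc(C(=O)O)c1)c1ccc(OCc2c(-c3c(Cl)cccc3Cl)noc2C2CC2)nc1C(F)(F)F` gives in this assay 102%; set against compound 1 this is a number 4 percentage points higher from compound 1 to compound 3 (within the scatter), and set against compound 2 it is a number 16 percentage points higher from compound 2 to compound 3 (beyond the scatter). Compound 4 `CC(Oc1ccc(C(=O)O)cc1)c1ccc(OCc2c(-c3c(Cl)cccc3Cl)noc2C2CC2)nc1C(F)(F)F` has not yet been measured in this assay. It differs from compound 3 by 4-carboxyphenyl in place of 3-carboxyphenyl on an oxygen on a saturated carbon. This is the same change as the one from compound 1 to compound 2, with the same surroundings at the place, and it occurs twice among these four compounds, once with both ends measured. The two cores differ by methyl in place of hydrogen on a saturated chain carbon bound to an aromatic carbon and an oxygen on an aromatic ring. In this assay the expected step is a number 12 percentage points lower from compound 3 to compound 4 (beyond the scatter), close to the measured one, because the earlier occurrence gave a number 12 percentage points lower from compound 1 to compound 2 (beyond the scatter) while the core difference itself gave only a number 4 percentage points higher from compound 1 to compound 3 (within the scatter). Compound 4 is estimated at 90%, with a range from 78% to 100%.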

Compound 4, largest response reached (reported as efficacy), in percent of the reference or control that the assay uses: 89%
For compound 4 the middle estimate is 1 percentage points above the measured one; the measured number falls inside the stated range.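

In this assay, 4-carboxyphenyl in place of 3-carboxyphenyl on the oxygen gives a number 13 percentage points lower from compound 3 to compound 4 (beyond the scatter), and this step carries over between the two cores: the same change on two cores in this assay, a number 12 percentage points lower (beyond the scatter) from compound 1 to compound 2 and a number 13 percentage points lower (beyond the scatter) from compound 3 to compound 4, 1 percentage points apart, within the scatter of two such steps

Methyl in place of hydrogen on the saturated chain carbon gives a number 3 percentage points higher from compound 2 to compound 4 (within the scatter), and with either carboxyphenyl group this change stays within the scatter: the same change on two cores in this assay, a number 4 percentage points higher (within the scatter) from compound 1 to compound 3 and a number 3 percentage points higher (within the scatter) from compound 2 to compound 4, 1 percentage points apart, within the scatter of two such steps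

The full replacement of (3-carboxyphenoxy)methyl by 1-(4-carboxyphenoxy)ethyl gives a number 9 percentage points lower from compound 1 to compound 4 (within the scatter), which fits these two steps, but the agreement rests on only these two closely related cores and on maximal response alone, so it shows neither that the step would carry to other cores nor how potency behaves.

The compounds shown leave open whether the step holds when a tetrazole or a primary amide takes the place of the carboxylic acid, or when an ethyl group takes the place of the methyl on the saturated chain carbon. Also open, from the compounds shown here alone, is whether it holds with a nitrile in place of the trifluoromethyl.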